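Dichlorophenyl variant of a piperazinyl thiazolidine amide

The source may report more compounds than this note shows. Statements on the series, on what has been measured and on what is new or still open speak of the compounds shown alone.

Measured compounds:
Compound 1 `N#Cc1ccnc(N2CCN([C@@H]3CN[C@H](C(=O)N4CCSC4)C3)CC2)c1` gives 1.9 nM in an assay on a cell-free system (plasma) for inhibition of Dipeptidyl peptidase 4 (Rattus norvegicus), read by fluorescence; on this read-out lower numbers stand for stronger inhibition and higher numbers for weaker inhibition.
Compound 2 `O=C([C@@H]1C[C@H](N2CCN(c3ccccc3Cl)CC2)CN1)N1CCSC1` gives 10.9 nM in this assay.

Compound 2 holds the higher of the two numbers, the step of a 5.7-fold higher number from compound 1 to compound 2 (0.76 log units; beyond the scatter) separating it from compound 1. Compound 3 `O=C([C@@H]1C[C@H](N2CCN(c3ccc(Cl)c(Cl)c3)CC2)CN1)N1CCSC1` differs from compound 2 by 3,4-dichlorophenyl in place of 2-chlorophenyl on an amine nitrogen in a ring. Within the data shown here, no measured step bears directly on this change; the only measured step, a 5.7-fold higher number from compound 1 to compound 2 (0.76 log units; beyond the scatter), concerns a different aryl exchange on the same nitrogen and was modest. Compound 3 is therefore expected to land close to compound 2, with any shift a 1.4-fold higher number from compound 2 to compound 3 (0.14 log units; within the scatter) likely within or near the scatter. The estimate for compound 3 is 15 nM, ranging from 5 nM to 50 nM.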

Compound 3, half-maximal inhibitory concentration: 4.2 nM
Compound 3: middle estimate off by 3.6-fold (0.55 log units), on the high side; measured number outside the range, below it.
By their numbers in this assay, from the lowest: compound 1; then compound 3; then compound 2.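

In this assay, the aryl group on this ring nitrogen still moves the number when one chlorophenyl group replaces another, with a 2.6-fold lower number from compound 2 to compound 3 (0.41 log units; beyond the scatter). The 3,4-dichlorophenyl group closes part of the gap to the 4-cyanopyridin-2-yl group but not all of it, leaving a 2.2-fold higher number from compound 1 to compound 3 (0.34 log units; beyond the scatter). Nothing available explains either step. The change alters the number of chlorines and their places together, and the compounds shown do not separate the two. From the compounds shown here alone, how a 4-chlorophenyl or a 4-methoxyphenyl group would compare stays open.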